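A few compounds are considered here, and "the series" means these few. Any claim that something is new, unique, unknown or untested is made for them only; others in the source may bear on it.

In an ADME assay on microsomes from liver (Homo sapiens) for metabolic stability, read by LC-MS, using NADPH, with a stated time of 10 min, tested at 10 uM (on this read-out lower numbers stand for a shorter-lived compound and higher numbers for a longer-lived compound), compound 1, `Nc1ncnc2c1c(Oc1cccc(C(F)(F)F)c1)nn2[C@H]1C[C@H](O)C1`, gives 1.25 h. Compound 3, `Nc1ncnc2c1c(Oc1cc(O)ccn1)nn2C1CCC(F)(F)CC1`, returns only a limit of this assay, > 2.41 h, and no number. Compound 2, `CO[C@H]1CC[C@H](n2nc(Oc3cc(C(F)(F)F)ccn3)c3c(N)ncnc32)CC1`, likewise returns only a limit, > 2.41 h. Two of the three values sit at the limit of > 2.41 h in this assay, at which 2 of the 3 values shown sit. Compound 2 therefore stands with the longer-lived pair in this assay, while its true half-life is not known.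

Compound 4, `Nc1ncnc2c1c(Oc1cc(C(F)(F)F)ccn1)nn2[C@H]1CC[C@H](CO)CC1`, differs from compound 2 by hydroxymethyl in place of methoxy on a saturated ring carbon; the two have the same atoms, joined differently, a hydroxymethyl entering where a methoxy leaves, on a saturated ring carbon of a six-membered non-aromatic ring of carbon only. Among the measured compounds shown here, no measured pair differs in one place, so the size of such a step in this assay is untested. A small downward step, or none beyond the scatter, is expected, and the step of an at least 1.2-fold lower number from compound 2 to compound 4 (0.08 log units; that floor lies within the scatter) is estimated accordingly. For compound 4 the half-life in this assay is expected to be 2 h, between 1 h and 2.41 h.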

Compound 4, half-life: > 2.41 h
Compound 4: no number, only a limit; the forecaster's own chance of this, stated with the estimate: 40%; middle value at least 1.2-fold (0.08 log units) from the limit.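

Compound 4 returns only a limit in this assay, > 2.41 h, and no number. Among the compounds shown here, compound 2 also carries only a limit, so no step between the two can be read. The compounds shown leave open what true half-life either compound has, and whether hydroxymethyl in place of methoxy changes it at all.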